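The source may hold more compounds than are shown below. What is called first, only, known or untested is meant among the compounds shown, and "the series" means these compounds.

Measured compounds:
compound 1 `CC1(C)Oc2cc(NS(=O)(=O)C3CCCCC3)ccc2NC1=O`, 30400 nM
compound 2 `CC1(C)Oc2cc(NS(=O)(=O)c3ccc(F)cc3Cl)ccc2NC1=O`, 27000 nM

Among the measured compounds shown here, in a functional assay on PC-3 cells (Homo sapiens) for antiproliferative activity, read by luminescence, with a stated time of 96 h (on this read-out higher numbers stand for weaker inhibition and lower numbers for stronger inhibition), compound 2 and compound 1 stand within the scatter of each other; the one measured step, a 1.1-fold lower number from compound 1 to compound 2 (0.05 log units; within the scatter), shows no movement beyond it. Compound 3 `CC1(C)Oc2cc(NS(=O)(=O)c3ccccc3)ccc2NC1=O` carries phenyl in place of 2-chloro-4-fluorophenyl on a sulfonyl sulfur. For the measured compounds named here, no measured step bears directly on this exchange of one aryl group for another; the single step at the sulfonyl sulfur changed nothing beyond the scatter. The expectation for compound 3 in this assay is therefore no step beyond the scatter, a 1.0-fold higher number from compound 2 to compound 3 (0.02 log units; within the scatter), with compound 3 estimated at 28000 nM (range 12000 nM to 65000 nM).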

Compound 3, half-maximal inhibitory concentration: 40100 nM
For compound 3 the middle estimate is 1.4-fold (0.16 log units) below the measured one; the range from low to high includes it.
By their numbers in this assay, from the lowest: compounds 2, 1 and 3 (each within the scatter of the next).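

In this assay phenyl on the sulfonyl sulfur gives a 1.5-fold higher number from compound 2 to compound 3 (0.17 log units; within the scatter) and a 1.3-fold higher number from compound 1 to compound 3 (0.12 log units; within the scatter) in the same series. Neither taking away the chlorine and fluorine of 2-chloro-4-fluorophenyl nor replacing cyclohexyl with phenyl moves the number beyond the scatter, so all three groups at this position read alike. No measurement on hand accounts for these values.

Still open, as far as these compounds go, is whether an amine, a carboxylic acid or a longer alkyl chain on the sulfonyl sulfur would move the number beyond the scatter. Changes to the shared core also remain untested in these compounds.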